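Shortening the Chain on a Bicyclic Core

The compounds below may be only part of what the source reports. "The series", "measured", "known", "first", "only" and "open" are said of these compounds alone.

Compound 1 `Cn1c(-c2ccccc2C(F)(F)F)nnc1C12CCC(CCCC(C)(F)F)(CC1)CC2`: > 4000 nM in an assay on CHO-K1 cells for inhibition of 11-beta-hydroxysteroid dehydrogenase type 2 (Mus musculus), read by scintillation proximity assay (on this read-out higher numbers stand for weaker inhibition and lower numbers for stronger inhibition), a limit of the assay.
Compound 2 `CCS(=O)(=O)CCCCC12CCC(c3nnc(-c4ccccc4C(F)(F)F)n3C)(CC1)CC2`: > 4000 nM in this assay, a limit of the assay.

Compound 2 therefore stands only at a limit in this assay. Going by the values given here, the step that the two limits leave unreadable from compound 1 to compound 2 cannot be read, the only evidence being (the limit of > 4000 nM in this assay, at which 2 of the 2 values shown sit). Compound 3 `CCOCC12CCC(c3nnc(-c4ccccc4C(F)(F)F)n3C)(CC1)CC2` differs from compound 2 by ethoxy in place of 3-(ethylsulfonyl)propyl on a saturated chain carbon bound to a saturated ring carbon. Among the compounds with values here, no measured step bears on this change, so no shift beyond the scatter is expected in this assay. Compound 3 is expected to give 8000 nM, within 2000 nM to 40000 nM, most likely again as a limit. The expected step is a step that the limit leaves unreadable from compound 2 to compound 3.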

Compound 3, half-maximal inhibitory concentration: > 4000 nM
Compound 3: no number, only a limit (the forecaster's own chance of this, stated with the estimate: 70%); the middle value is on the limit's open side.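

Compound 3 sits at a limit in this assay, as do compound 1 and compound 2, so no step among these compounds can be read: the limit of > 4000 nM in this assay, at which 3 of the 3 values shown sit.

The compounds shown leave open how strongly, if at all, any of them inhibits the enzyme.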